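This account rests on a few compounds, and the source may have more. Where it says the series, first, only, none or still open, it means among the compounds named here.

Going by the values given here, compound 2 `CC[C@H](C)[C@H](N)CN(C(=O)[C@@H]1C[C@H]1c1ccc(Cl)cc1)c1ccc(-c2ccccc2)cc1` stands at the higher of the two numbers measured so far. In a functional assay for agonist activity at G protein-coupled receptor 88 (Homo sapiens), read by HTRF and cAMP accumulation (a lower number here means that less compound is needed, a higher number that more compound is needed for the effect), compound 2 gives 4300 nM, while compound 1 `O=C([C@@H]1C[C@H]1c1ccccc1)N(CC1CCCNC1)c1ccc(-c2ccccc2)cc1` gives 10 nM, a gap that is well beyond the usual scatter. Compound 3 `CC[C@H](C)[C@H](N)CN(C(=O)[C@@H]1C[C@H]1c1cccc(OC)c1)c1ccc(-c2ccccc2)cc1` carries a single change: 3-methoxyphenyl in place of 4-chlorophenyl on a saturated ring carbon of the three-membered ring. Among the compounds with values here, with no comparable step among the measured pairs, the expected change from compound 2 is a 1.4-fold higher number from compound 2 to compound 3 (0.14 log units; within the scatter), a small shift toward needing more compound. Compound 3 is thus estimated at 6000 nM, within a range of 2000 nM to 20000 nM.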

Compound 3, half-maximal effective concentration: 3000 nM
Estimate against measurement, compound 3: 2.0-fold (0.30 log units) above; measured number inside the range.
By their numbers in this assay, from the lowest: compound 1; then compounds 3 and 2 (each within the scatter of the next).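

In this assay, putting 3-methoxyphenyl in place of 4-chlorophenyl on a saturated ring carbon of the three-membered ring gives a 1.4-fold lower number from compound 2 to compound 3 (0.16 log units; within the scatter), so this first step at the position leaves the two compounds within the scatter of each other. Here, a different substituent at a different place on the phenyl ring does not separate them. No available evidence accounts for this result. Since the substituent and its place differ together, 3-chlorophenyl and 4-methoxyphenyl would be needed to read each alone. On these data alone, whether an aminophenyl group behaves likewise also remains open.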